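The source may report more compounds than this note shows. Statements on the series, on what has been measured and on what is new or still open speak of the compounds shown alone.

Among the compounds with values here, compound 1 `CC(C)(C)c1ccc(C(=O)N2CCC3(CC2)C(=O)N(CC(=O)N2CCN(S(C)(=O)=O)CC2)CN3c2ccccc2)cc1` is one of two compounds measured in an assay on HEK293 cells for displacement of a labelled ligand from NPC1-like intracellular cholesterol transporter 1 (Homo sapiens) (on this read-out higher numbers stand for weaker inhibition and lower numbers for stronger inhibition), where compound 1 gives 19000 nM. That is the higher of the two numbers. Compound 2 `CS(=O)(=O)N1CCN(C(=O)CN2CN(c3ccccc3)C3(CCN(C(=O)c4ccc(C5CCCCC5)cc4)CC3)C2=O)CC1` differs from it in one place, and in this assay compound 2 gives 6300 nM; the step between them reads a 3.0-fold lower number from compound 1 to compound 2 (0.48 log units; beyond the scatter). Compound 3 `CC(C)(C)c1ccc(C(=O)N2CCC3(CC2)C(=O)N(CC(=O)NCCCCO)CN3c2ccccc2)cc1` is not yet measured. It differs from compound 1 in a different way: (4-hydroxybutyl)amino in place of 4-(methylsulfonyl)piperazin-1-yl on a carbonyl carbon. Within the data shown here, the single measured step alters a group on an aromatic carbon, not the carbonyl carbon where compound 3 differs, so no measured step speaks to this change; the two numbers only show that both measured compounds are weak inhibitors. With nothing pointing either way, compound 3 is expected to stay close to compound 1, the estimated step being no change at the digits printed from compound 1 to compound 3 (within the scatter). The estimate for compound 3 is 19000 nM, with a range from 5000 nM to 70000 nM.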

Compound 3, half-maximal inhibitory concentration: 19200 nM
Beside the measured number, compound 3's estimate is 1.0-fold (0.00 log units) below it; the range from low to high includes it.
By their numbers in this assay, from the lowest: compound 2; then compounds 1 and 3 (each within the scatter of the next).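

At the carbonyl carbon, replacing 4-(methylsulfonyl)piperazin-1-yl with (4-hydroxybutyl)amino gives a 1.0-fold higher number from compound 1 to compound 3 (0.00 log units; within the scatter) in this assay, so this pair shows no measurable difference. The earlier step spoke only to a group on an aromatic carbon, whereas this one shows that, with the tert-butyl group in place, an open chain with a terminal hydroxyl and a six-membered ring carrying a methylsulfonyl group read alike at this carbonyl carbon. No measurement at hand accounts for that likeness.

Going by these compounds, it remains open whether a carboxylic acid, an amine or a longer chain at this carbonyl carbon would also leave the number in place. Also open, on these data alone, is how (4-hydroxybutyl)amino behaves alongside the cyclohexyl group of compound 2.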